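Adding a Methyl to the Sulfonamide Nitrogen

The compounds below may be only part of what the source reports. "The series", "measured", "known", "first", "only" and "open" are said of these compounds alone.

In a functional assay on A549 cells (Homo sapiens) for inhibition (on this read-out higher numbers stand for weaker inhibition of growth and lower numbers for stronger inhibition of growth), compound 1, `O=S(=O)(Nc1ccccc1)c1ccccc1`, is recorded only as a limit, > 80000 nM. Within the data shown here, compound 2, `CC(C)(C)c1ccc(S(=O)(=O)Nc2ccccc2)cc1`, gives 16000 nM, the only true number available in this assay so far. Among the measured compounds shown here, the sole measured step is an at least 5.0-fold lower number from compound 1 to compound 2 (0.69 log units; beyond the scatter), made by tert-butyl in place of hydrogen on an aromatic carbon. Going by these compounds, it starts from a limit, (the limit of > 80000 nM in this assay, at which 1 of the 2 values shown sits), so its full size remains open.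

Compound 3, `CN(c1ccccc1)S(=O)(=O)c1ccc(C(C)(C)C)cc1`, differs from compound 2 by methyl in place of hydrogen on a sulfonamide nitrogen, (methyl in place of hydrogen on a sulfonamide nitrogen). For the measured compounds named here, the measured step bears on this change only weakly, since it concerns a different place on the molecule, and no measured pair changes the sulfonamide nitrogen. Its size therefore gives no direct guide, and no direction can be drawn from it. With compound 2 at 16000 nM as the anchor, no step beyond the scatter is expected, though the uncertainty is wide in both directions. The expected change is a 1.1-fold higher number from compound 2 to compound 3 (0.05 log units; within the scatter). For compound 3 the estimated value is 18000 nM, with an expected range of 6000 nM to 60000 nM.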

Compound 3, concentration for 50% growth inhibition: 30000 nM
Beside the measured number, compound 3's estimate is 1.7-fold (0.22 log units) below it, and the stated range covers the measured number.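

In this assay, among these compounds, methyl in place of hydrogen on a sulfonamide nitrogen gives a 1.9-fold higher number from compound 2 to compound 3 (0.27 log units; within the scatter), the first measured step at this position. For this one pair, carrying the tert-butyl group, the hydrogen on the sulfonamide nitrogen can give way to methyl without a step beyond the scatter, so the growth inhibition first measured with compound 2 is still seen with compound 3. Nothing at hand gives a cause for this step.

The compounds shown leave open how a longer chain such as ethyl, or an acetyl group, on the same nitrogen would read in this assay. They also leave open whether methyl on this nitrogen would read the same way without the tert-butyl group, and compound 1, which lacks that group, is recorded only as a limit, > 80000 nM.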